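From hydroxy to methoxy on the shared core

The source may report more compounds than this note shows. Statements on the series, on what has been measured and on what is new or still open speak of the compounds shown alone.

Measured in a functional assay on A549 cells (Homo sapiens) for cytotoxicity, read by MTT assay; a lower number here means a stronger inhibitor, a higher number a weaker inhibitor:
- compound 1 `C=C1C(=O)[C@]23C[C@@]1(O)CC[C@H]2[C@@]12C=CC(=O)[C@](C)(C(=O)O1)[C@H]2[C@@H]3C(=O)OC`: 90900 nM
- compound 2 `C=C1C(=O)[C@]23C[C@@]1(O)CC[C@H]2[C@@]12C=CC(=O)[C@](C)(C(=O)O1)[C@H]2[C@@H]3C(=O)OCc1ccccc1`: 23900 nM
- compound 3 `C=C1C(=O)[C@]23C[C@@]1(OCC)CC[C@H]2[C@@]12C=CC(=O)[C@](C)(C(=O)O1)[C@H]2[C@@H]3C(=O)OC`: 18200 nM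

Only compound 1 stands apart in these numbers, as a 3.8-fold lower number from compound 1 to compound 2 (0.58 log units; beyond the scatter) shows. Compound 2 and compound 3 lie within the scatter of each other.

Compound 4 `C=C1C(=O)[C@]23C[C@@]1(OC)CC[C@H]2[C@@]12C=CC(=O)[C@](C)(C(=O)O1)[C@H]2[C@@H]3C(=O)OCc1ccccc1` differs from compound 2 by methyl in place of hydrogen on an oxygen on a saturated carbon, so hydroxy becomes methoxy. The closest evidence is a 5.0-fold lower number from compound 1 to compound 3 (0.70 log units; beyond the scatter), where ethyl replaced the hydrogen on that oxygen. That step involved ethyl rather than methyl, and it was measured without the phenyl that compound 2 carries. For the measured compounds named here, no measured compound combines both changes, so whether the two steps add up is unknown. A modest step towards a lower number is therefore expected in this assay, probably somewhat smaller than the ethyl step. The estimated change is a 2.7-fold lower number from compound 2 to compound 4 (0.42 log units; beyond the scatter). Compound 4 is expected at 9000 nM, within an estimated range of 3500 nM to 22000 nM.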

Compound 4, half-maximal inhibitory concentration: 28200 nM
Compound 4: middle estimate off by 3.1-fold (0.50 log units), on the low side, and the stated range ends below it.
By their numbers in this assay, from the lowest: compounds 3, 2 and 4 (each within the scatter of the next); then compound 1.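

On the compound carrying the phenyl, replacing the hydrogen on the oxygen with methyl, so that hydroxy becomes methoxy, has no effect that can be told from the scatter in this assay (a 1.2-fold higher number from compound 2 to compound 4 (0.07 log units; within the scatter)). This position therefore does not respond in the same way in every case, since the ethyl step without the phenyl, a 5.0-fold lower number from compound 1 to compound 3 (0.70 log units; beyond the scatter), lies beyond the scatter. Nothing available accounts for this contrast.

The compounds shown leave open whether the contrast follows from ethyl versus methyl or from the presence of the phenyl, as methoxy on compound 1 and ethoxy on compound 2 do not appear among them. Going by these compounds, how a longer chain such as butyl on that oxygen would read also remains open.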